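Oxime ether series in rat paw edema: cyano to dimethylamino

This account rests on a few compounds, and the source may have more. Where it says the series, first, only, none or still open, it means among the compounds named here.

Working notes on the series. Three compounds of the shared core have been run in a functional assay on the whole organism for inhibition, with Rattus norvegicus as the target, read by paw edema, with stated times of 1 h and 3 h, at a dose of 50 mg/kg by the oral route; a lower number here means less inhibition, a higher number more inhibition at the dose given (going by the name of the read-out). Compound 1 `C/C(=N\OCC(=O)O)c1ccccc1Cl` returns only an assay limit, < 20%. Compound 2 `C/C(=N\OCC(=O)O)c1cccc(Cl)c1` gives 20%. Compound 3 `C/C(=N\OCC(=O)O)c1ccc(C#N)cc1` likewise returns an assay limit, < 20%, so no number is known for it. Among the compounds with values here, the picture across the three is the limit of < 20% in this assay, at which 2 of the 3 values shown sit, and no step between measured compounds can be drawn from it. Compound 4 `C/C(=N\OCC(=O)O)c1ccc(N(C)C)cc1` differs from compound 3 by dimethylamino in place of cyano on an aromatic carbon. The estimate for this assay implies a step that the limit leaves unreadable from compound 3 to compound 4, expected to be none beyond the scatter. Compound 4 is expected to give 18% in this assay, within 5% to 38%.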

Compound 4, a percentage reported as inhibition, in the whole organism at one dose (the size of the read-out at that dose, not a potency): < 20%
Compound 4 gave a limit, no number (the forecaster's own chance of this, stated with the estimate: 55%); the middle value lies beyond the limit too.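

No step can be read from compound 3 to compound 4, since both return only limits in this assay: the limit of < 20% in this assay, at which 3 of the 4 values shown sit.

The compounds shown leave open whether dimethylamino in place of cyano on an aromatic carbon changes inhibition at all.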